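A few compounds are considered here, and "the series" means these few. Any claim that something is new, unique, unknown or untested is made for them only; others in the source may bear on it.

Measured so far:
compound 1 `Cc1ccc(-c2nc(=O)o[nH]2)c(-c2ccc([C@@H](C)N(CC3CC3)c3nc4c(C(=O)O)cccc4o3)cc2)c1` — 2.8 h
compound 2 `CCCCN(c1nc2c(C(=O)NC)cccc2o1)[C@H](C)c1ccc(-c2ccccc2-c2nnn[nH]2)cc1` — 1.3 h
compound 3 `C[C@H](c1ccc(-c2cc(F)ccc2-c2nc(=O)o[nH]2)cc1)N(CC1CC1)c1nc2c(C(=O)O)cccc2o1` — 4.1 h

In an ADME assay on the whole organism (Macaca fascicularis) for metabolic stability, read by LC-MS, using cassette dosing, at a dose of 1 mg/kg by the oral route (on this read-out higher numbers stand for a longer-lived compound and lower numbers for a shorter-lived compound), compound 2 gives the lowest of the three numbers, 1.3 h. Compound 1 gives 2.8 h and compound 3 gives 4.1 h, each beyond the scatter above compound 2. Compound 4 `CCCCN(c1nc2c(-c3nccn3C)cccc2o1)[C@H](C)c1ccc(-c2ccccc2-c2nnn[nH]2)cc1` differs from compound 2 in one place: 1-methyl-1H-imidazol-2-yl in place of methylcarbamoyl on an aromatic carbon. Among the measured compounds shown here, the only measured step, a 1.5-fold higher number from compound 1 to compound 3 (0.17 log units; within the scatter), concerns a different change and does not bear on this one, so nothing measured here predicts the size or direction of the move. Without such guidance, the step of a 1.2-fold higher number from compound 2 to compound 4 (0.06 log units; within the scatter) is expected to stay within the scatter. Compound 4 is accordingly estimated at 1.5 h, with a range from 0.6 h to 3.5 h.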

Compound 4, half-life: 3.9 h
Beside the measured number, compound 4's estimate is 2.6-fold (0.41 log units) below it; measured number outside the range, above it.
By their numbers in this assay, from the lowest: compound 2; then compounds 1, 4 and 3 (each within the scatter of the next).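

Among the compounds shown here, compound 2 and compound 4 show that this aromatic carbon is not indifferent in this assay: 1-methyl-1H-imidazol-2-yl in place of methylcarbamoyl gives a 3.0-fold higher number from compound 2 to compound 4 (0.48 log units; beyond the scatter), whereas the only earlier step, at another place, stayed within the scatter. Replacing this amide with an aromatic ring therefore moved the half-life here, on this one pair. Nothing available explains the move. The compounds shown leave open whether the ring or its methyl matters, as an imidazol-2-yl without the methyl or a pyridine ring would test. They also leave open how a carboxylic acid on this carbon would behave with everything else as in compound 2.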